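Removing the acetoxy group from a brominated furanone

The source may hold more compounds than are shown below. What is called first, only, known or untested is meant among the compounds shown, and "the series" means these compounds.

Compound 1 `CCC[C@@H](OC(C)=O)C1=C(Br)C(=C(Br)Br)OC1=O`: < 0.1 ug/mL
Compound 2 `CCCCCCC(=O)C(Br)=C(Br)Br`: > 20 ug/mL
Compound 3 `CCCCC1=C(Br)C(OC)(C(Br)Br)OC1=O`: 6.7 ug/mL

Of the compounds shown here, three have been measured in a functional assay on ZR-75-1 cells (Homo sapiens) for cytotoxicity; a lower number here means that less compound is needed, a higher number that more compound is needed for the effect. Compound 1 gives < 0.1 ug/mL, which is a limit of the assay rather than a number (the limit of < 0.1 ug/mL in this assay, at which 1 of the 3 values shown sits). Compound 2 gives > 20 ug/mL, also a limit and not a number (the limit of > 20 ug/mL in this assay, at which 1 of the 3 values shown sits). Compound 3 gives 6.7 ug/mL, the only exact figure among the three. Compound 1 therefore stands at the low edge of what this assay reports, with compound 2 at the high edge and compound 3 between them; how far compound 1 actually lies from the others cannot be told from a limit.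

No pair of these compounds differs in only one place, so no measured step is available. Compound 4 `CCCCC1=C(Br)C(=C(Br)Br)OC1=O` differs from compound 1 in one place: hydrogen in place of acetoxy on a saturated chain carbon bound to a double-bonded ring carbon and a saturated chain carbon. The ring with its exocyclic dibromomethylene is kept, while the acetoxy on the side chain is lost.

For the measured compounds named here, with no comparable step measured, the size and direction of this change are open. Compound 4 is expected to give about 1 ug/mL, somewhere between 0.1 ug/mL and 10 ug/mL, which would mean an expected step of an at least 10-fold higher number from compound 1 to compound 4 (1.00 log units; beyond the scatter) in this assay.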

Compound 4, concentration for half-maximal effect: 8.6 ug/mL
Beside the measured number, compound 4's estimate is 8.6-fold (0.93 log units) below it; the range from low to high includes it.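

In this assay, for the compounds shown here, the exchange of acetoxy for hydrogen on this saturated chain carbon gives an at least 86-fold higher number from compound 1 to compound 4 (1.93 log units; beyond the scatter) and is the first measured step in this set. The ring with its exocyclic dibromomethylene stays the same, so this single change accounts for the whole step, and the chain carbon that carries the acetoxy is clearly not a place where the group can be dropped without consequence in this assay. The size of the step is a minimum and not an exact figure, as the value of compound 1 is a limit of the assay: the limit of < 0.1 ug/mL in this assay, at which 1 of the 4 values shown sits.

The compounds shown do not tell whether the whole acetoxy group matters or only the oxygen on this carbon, a question that a hydroxyl group in the same place on the shared core could help to settle, and they do not show how a longer ester would fare. The reason for the large step also stays open: nothing shown here speaks to it.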